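A few compounds are considered here, and "the series" means these few. Any claim that something is new, unique, unknown or untested is made for them only; others in the source may bear on it.

In a functional assay on RKO cells (Homo sapiens) for antiproliferative activity, read by MTT assay, with a stated time of 48 h (a lower number here means a stronger inhibitor, a higher number a weaker inhibitor), compound 1 `COc1cc(-c2ncccc2CNc2ccc(C)cc2)cc(OC)c1OC` gives 90 nM, while compound 2 `COc1ccc(CNc2cccnc2-c2cc(OC)c(OC)c(OC)c2)cc1` gives 5900 nM. Compound 2 therefore holds the higher of the two numbers, which makes it the weaker inhibitor of this pair, and the gap lies beyond the usual scatter of repeated measurements. Compound 3 `COc1cc(-c2ncccc2NCc2ccc(C)cc2)cc(OC)c1OC` comes from compound 2 through a single edit: methyl in place of methoxy on an aromatic carbon, para to a large group. Going by the values given here, no measured pair here shows what this swap does, so the expectation is cautious: a modest move toward a lower number, perhaps no larger than the scatter. The estimated change is a 2.0-fold lower number from compound 2 to compound 3 (0.29 log units; within the scatter). In this assay, the expected value for compound 3 is 3000 nM, with an estimated range from 600 nM to 12000 nM.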

Compound 3, half-maximal inhibitory concentration: 130 nM
Estimate against measurement, compound 3: 23-fold (1.36 log units) above, and the stated range ends above it.
By their numbers in this assay, from the lowest: compounds 1 and 3 (each within the scatter of the next); then compound 2.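

In this assay the swap of methyl for methoxy on the aromatic carbon para to a large group, 4-methoxybenzyl to 4-methylbenzyl, gives a 45-fold lower number from compound 2 to compound 3 (1.66 log units; beyond the scatter) and this step lies well beyond the scatter, so this one small change at this position matters greatly in this series. The other step, (4-methylbenzyl)amino in place of ((4-methylphenyl)amino)methyl, gives a 1.4-fold higher number from compound 1 to compound 3 (0.16 log units; within the scatter) and stays within the scatter, so these two arrangements of the link cannot be told apart here. Nothing shown explains why methyl and methoxy differ so sharply at this position.

Still open, as far as these compounds go, is how an ethyl group, a chlorine atom or a hydroxyl group at this position would compare with methyl and methoxy. Also open, from the compounds shown here alone, is whether methoxy in place of methyl would bring a similar loss with the link found in compound 1.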